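Chloro to Methyl on the Aryl Ketone Arm of Compound 3

The source may report more compounds than this note shows. Statements on the series, on what has been measured and on what is new or still open speak of the compounds shown alone.

Compound 1, `CCc1nnc(SCC(=O)c2ccc(C)cc2)n1N1C(=O)c2ccccc2C1=O`: > 200000 nM
Compound 2, `C#CCSc1nnc(-c2cc(OC)c(OC)c(OC)c2)n1N1C(=O)c2ccccc2C1=O`: > 200000 nM
Compound 3, `COc1cc(-c2nnc(SCC(=O)c3ccc(Cl)cc3)n2N2C(=O)c3ccccc3C2=O)cc(OC)c1OC`: 20700 nM

In a functional assay on PC-3M cells (Homo sapiens) for cytotoxicity, read by MTT assay, with a stated time of 48 h (on this read-out higher numbers stand for weaker inhibition and lower numbers for stronger inhibition), compound 1 reaches only a limit, > 200000 nM. Compound 2 likewise reaches only a limit in this assay, > 200000 nM. Two of the three values are therefore (the limit of > 200000 nM in this assay, at which 2 of the 3 values shown sit). Among the compounds with values here, compound 3 is the one compound with an actual number, 20700 nM in this assay, and so stands alone among the measured compounds.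

Compound 4, `COc1cc(-c2nnc(SCC(=O)c3ccc(C)cc3)n2N2C(=O)c3ccccc3C2=O)cc(OC)c1OC`, differs from compound 3 by methyl in place of chloro on an aromatic carbon. Within the data shown here, only one measured step exists, an at least 9.6-fold lower number from compound 2 to compound 3 (0.98 log units; beyond the scatter), and it exchanges a whole (4-chlorophenyl)carbonyl for ethynyl, a much larger change than the one from compound 3 to compound 4. Among the measured compounds shown here, no measured pair isolates chloro against methyl on that ring. Compound 1 carries the (4-methylphenyl)carbonyl arm of compound 4 but a different group on the shared core, so its limit and the number of compound 3 cannot be read as a step.

A small change of this kind is expected to stay within the scatter, and the step of a 1.4-fold higher number from compound 3 to compound 4 (0.16 log units; within the scatter) is the author's estimate. Compound 4 is therefore expected to give about 30000 nM in this assay, within 12000 nM to 120000 nM.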

Compound 4, half-maximal inhibitory concentration: 11700 nM
Beside the measured number, compound 4's estimate is 2.6-fold (0.41 log units) above it; measured number outside the range, below it.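

The exchange of chloro for methyl on the aromatic carbon para to a large group gives a 1.8-fold lower number from compound 3 to compound 4 (0.25 log units; within the scatter), so the 4-chlorophenyl and 4-methylphenyl arms are not told apart in this assay. Within the data shown here, the 4-methylphenyl arm also gives two readings that the earlier compounds could not: with the arm held constant, 3,4,5-trimethoxyphenyl in place of ethyl on the shared core gives an at least 17-fold lower number from compound 1 to compound 4 (1.23 log units; beyond the scatter), and with the 3,4,5-trimethoxyphenyl held constant, (4-methylphenyl)carbonyl in place of ethynyl gives an at least 17-fold lower number from compound 2 to compound 4 (1.23 log units; beyond the scatter). Both large steps start from a limit of the assay, so each gives only a minimum size: the limit of > 200000 nM in this assay, at which 2 of the 4 values shown sit.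

With only chloro and methyl shown on that ring, the compounds leave open what a methoxy group, a nitrile or a plain hydrogen at the same place would give in this assay. Going by these compounds, it also remains open whether a single methoxy group or an amine in place of the 3,4,5-trimethoxyphenyl would still give a number rather than a limit.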